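The source may report more compounds than this note shows. Statements on the series, on what has been measured and on what is new or still open speak of the compounds shown alone.

Working notes on the series, read in a functional assay on MCF7 cells (Homo sapiens) for inhibition, read by MTT assay, with a stated time of 96 h; a higher number here means a weaker inhibitor of growth, a lower number a stronger inhibitor of growth. Compound 1 `Cc1cc(C(=O)NCCCCCCS)[nH]n1` carries methyl on the shared core. Compound 1 gives > 50000 nM, which is a limit of the assay and not a number. Compound 2 `O=C(NCCCCCCS)c1cc(C2CCCCC2)n[nH]1` carries cyclohexyl on the same aromatic carbon. Compound 2 gives > 50000 nM, again a limit and not a number. Compound 2 therefore has no numeric standing in this assay, and the whole record so far is the limit of > 50000 nM in this assay, at which 2 of the 2 values shown sit.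

The next change leads to compound 3 `O=C(NCCCCCCS)c1cc(-c2cnccn2)n[nH]1`, with pyrazin-2-yl in place of cyclohexyl on an aromatic carbon. Among the compounds with values here, the only measured step that bears on it is a step that the two limits leave unreadable from compound 1 to compound 2, which has no readable size, so no size or direction carries over from it. In this assay the expected step is a number no higher from compound 2 to compound 3 (the limit leaves the size open), and no change beyond the scatter is anticipated. Compound 3 is estimated at 50000 nM, with an expected range of 20000 nM to 100000 nM, and the assay is expected most likely to report only a limit again.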

Compound 3, concentration for 50% growth inhibition: > 50000 nM
Compound 3: no number, only a limit; the forecaster's own chance of this, stated with the estimate: 80%; the middle value lies on the limit itself.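

Compound 3 gives > 50000 nM in this assay, a limit and not a number, so no step among compound 1, compound 2 and compound 3 can be read, and all three share one record: the limit of > 50000 nM in this assay, at which 3 of the 3 values shown sit.

The compounds shown leave open whether any group on this aromatic carbon gives a numeric value in this assay and how the three compounds would rank.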